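The source may report more compounds than this note shows. Statements on the series, on what has been measured and on what is new or still open speak of the compounds shown alone.

Of the compounds shown here, three that share one core have been measured for antiproliferative activity. Compound 1 `C=CS(=O)(=O)N1CCN(c2ncnc3sc(-c4ccc(C(F)(F)F)cc4)cc23)CC1` gives 7080 nM in a functional assay on MDA-MB-436 cells (Homo sapiens) for antiproliferative activity, read by MTT assay, with a stated time of 48 h; on this read-out higher numbers stand for weaker inhibition and lower numbers for stronger inhibition. Compound 2 `C=CS(=O)(=O)N1CCN(c2ncnc3sc(-c4ccc(OC)cc4)cc23)CC1` gives 28400 nM, and compound 3 `C=CS(=O)(=O)N1CCN(c2ncnc3sc(-c4ccc(N5CCN(C)CC5)cc4)cc23)CC1` gives 8760 nM. Compound 3 stands second highest of the three numbers: the step of a 1.2-fold higher number from compound 1 to compound 3 (0.09 log units; within the scatter) lies within the scatter, while the step of a 3.2-fold lower number from compound 2 to compound 3 (0.51 log units; beyond the scatter) lies beyond it. Compound 4 `CN1CCN(c2ccc(-c3cc4c(N5CCN(C(=O)Nc6cccc(F)c6)CC5)ncnc4s3)cc2)CC1` differs from compound 3 in one place: (3-fluorophenyl)carbamoyl in place of vinylsulfonyl on an amine nitrogen in a ring. Every measured step alters the group on the aromatic carbon and leaves the ring nitrogen untouched, so none of them bears on this change, and no direction beyond the scatter can be foreseen. Compound 4 is therefore estimated at 10000 nM, within a range of 2000 nM to 50000 nM. This amounts to an expected 1.1-fold higher number from compound 3 to compound 4 (0.06 log units; within the scatter).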

Compound 4, half-maximal inhibitory concentration: 18300 nM
Beside the measured number, compound 4's estimate is 1.8-fold (0.26 log units) below it, and the stated range covers the measured number.
By their numbers in this assay, from the lowest: compounds 1 and 3 (each within the scatter of the next); then compounds 4 and 2 (each within the scatter of the next).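

The earlier steps shown here varied only the group on the aromatic carbon, whereas swapping vinylsulfonyl for (3-fluorophenyl)carbamoyl on the ring nitrogen gives a 2.1-fold higher number from compound 3 to compound 4 (0.32 log units; beyond the scatter) in this assay. The group on this nitrogen therefore affects the read-out, and the larger group with an aromatic ring gives modestly weaker inhibition without abolishing it. No measurement here explains this shift.

This single swap removes one group and adds another, leaving their separate contributions unresolved. An acetyl or unsubstituted phenylcarbamoyl group on the same nitrogen would help separate them.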